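The source may hold more compounds than are shown below. What is called first, only, known or untested is meant among the compounds shown, and "the series" means these compounds.

Measured so far in an ADME assay on microsomes from liver (Mus musculus) for metabolic stability, read by LC-MS, using NADPH, with a stated time of 45 min, tested at 0.5 uM; a lower number here means slower removal, a higher number faster removal of the compound:
compound 1 `CCN(CC)C(=O)CCSc1nc2cc(Cl)ccc2o1` gives 108 mL/min/g
compound 2 `CN1CCN(C(=O)CCSc2nc3cc(Cl)ccc3o2)CC1` gives 41.5 mL/min/g

Compound 2 stands lowest of the two numbers; its nearest neighbour is compound 1, separated by a 2.6-fold lower number from compound 1 to compound 2 (0.42 log units; beyond the scatter). Compound 3 `CN(C)C(=O)CCSc1nc2cc(Cl)ccc2o1` is not yet measured. It differs from compound 2 in one place: dimethylamino in place of 4-methylpiperazin-1-yl on a carbonyl carbon. Going by the values given here, the only step bearing on this change is a 2.6-fold lower number from compound 1 to compound 2 (0.42 log units; beyond the scatter), which the move to dimethylamino largely reverses, since dimethylamino resembles the diethylamino of compound 1 more than the ring it replaces. For compound 3 a rise beyond the scatter is therefore expected, a 1.9-fold higher number from compound 2 to compound 3 (0.29 log units; within the scatter). Compound 3 is estimated at 80 mL/min/g, with a range of 35 mL/min/g to 180 mL/min/g.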

Compound 3, intrinsic clearance in a liver preparation (reported as CLH), per the amount of preparation that the assay uses: 41.8 mL/min/g
Compound 3: middle estimate off by 1.9-fold (0.28 log units), on the high side; the range from low to high includes it.
By their numbers in this assay, from the lowest: compounds 2 and 3 (each within the scatter of the next); then compound 1.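

On this carbonyl carbon in this assay, the 4-methylpiperazin-1-yl ring and open-chain dimethylamino cannot be told apart: a 1.0-fold higher number from compound 2 to compound 3 (0.00 log units; within the scatter). The ring is therefore not required for the number seen with compound 2, since a 2.6-fold lower number from compound 1 to compound 3 (0.41 log units; beyond the scatter), a step of the same printed size as that to the ring. No measurement on hand accounts for this. Open, as far as these compounds go, is where ethylmethylamino or morpholin-4-yl would fall on this carbonyl carbon. Also open, from the compounds shown here alone, is how far this holds with any other group on the shared core.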